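The compounds below may be only part of what the source reports. "The series", "measured", "known", "first", "only" and "open" are said of these compounds alone.

Going by the values given here, compound 2 `COc1cc(NC(C)CCCNC(=O)NNC(=O)Nc2ccc(F)cc2)c2ncccc2c1` gives 118000 nM in a functional assay on CCRF-CEM cells (Homo sapiens) for inhibition, read by MTT assay, with a stated time of 72 h (on this read-out higher numbers stand for weaker inhibition and lower numbers for stronger inhibition), the highest of the two numbers so far; compound 1 `COc1cc(NC(C)CCCNC(=O)Nc2ccc(C(F)(F)F)cc2)c2ncccc2c1` gives 14000 nM. Compound 3 `COc1cc(NC(C)CCCNC(=O)Nc2cccc(C(F)(F)F)c2)c2ncccc2c1` differs from compound 2 in one place: 3-(trifluoromethyl)phenyl in place of ((4-fluorophenyl)carbamoyl)amino on an amide-type nitrogen. Among the compounds with values here, the only step measured, an 8.4-fold higher number from compound 1 to compound 2 (0.93 log units; beyond the scatter), went the opposite way, trading a trifluoromethylphenyl group for the ((4-fluorophenyl)carbamoyl)amino group, so its reversal is the expectation here, with the estimated step of a 7.9-fold lower number from compound 2 to compound 3 (0.90 log units; beyond the scatter) bringing compound 3 back near compound 1. Compound 3 is therefore expected at about 15000 nM, within 5000 nM to 45000 nM.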

Compound 3, half-maximal inhibitory concentration: 19000 nM
Compound 3: the middle estimate sits 1.3-fold (0.10 log units) below what was measured; the range from low to high includes it.
By their numbers in this assay, from the lowest: compounds 1 and 3 (each within the scatter of the next); then compound 2.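

In this assay, 3-(trifluoromethyl)phenyl in place of ((4-fluorophenyl)carbamoyl)amino on the amide-type nitrogen gives a 6.2-fold lower number from compound 2 to compound 3 (0.79 log units; beyond the scatter) and so recovers the inhibition lost in compound 2. The change from 4-(trifluoromethyl)phenyl to 3-(trifluoromethyl)phenyl gives a 1.4-fold higher number from compound 1 to compound 3 (0.13 log units; within the scatter) and so does not separate these two groups. As far as these compounds go, whether an amine or a carboxylic acid in place of the trifluoromethyl would keep this level of inhibition stays open, as does the effect of a longer chain on the amide-type nitrogen. No supporting measurement explains either step.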